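Azido for chloro on the shared core: expected inhibition

The source may report more compounds than this note shows. Statements on the series, on what has been measured and on what is new or still open speak of the compounds shown alone.

Working notes on a small set tested in a functional assay on EL4 cells (Mus musculus) for inhibition, tested at 100 uM; a lower number here means less inhibition, a higher number more inhibition at the concentration tested (going by the name of the read-out). The shared core is that of compound 1, `Clc1[nH]ccc2ncnc1-2`. In this assay compound 1 gives < 5%, which is a limit of the assay and not a number; compound 1 therefore stands at the limit of < 5% in this assay, at which 1 of the 2 values shown sits. Among the compounds with values here, the only other measured compound, compound 2, `OCCNc1nccc2c1ncn2C1O[C@H](CO)[C@@H](O)[C@H]1O`, gives 6% in this assay, so both measured values lie at or near the bottom of the read-out, within the scatter of one another. Within the data shown here, no step between measured compounds is at hand. The change from compound 1 to compound 3, `[N-]=[N+]=Nc1[nH]ccc2ncnc1-2`, is azido in place of chloro on an aromatic carbon, azido entering where chloro leaves on an aromatic carbon. Among the measured compounds shown here, with both measured values low and no measured step to draw on, the step of a number no lower from compound 1 to compound 3 (the limit leaves the size open) is expected to be none beyond the scatter. Compound 3 is estimated at 5% in this assay, in a range from 0% to 15%.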

Compound 3, a percentage reported as inhibition, at one concentration (the size of the read-out at that concentration, not a potency): < 5%
Compound 3: no number, only a limit (the forecaster's own chance of this, stated with the estimate: 50%); the middle value sits exactly at the limit.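

Compound 1 and compound 3 both stand at a limit of this assay, not at a number, so no step between them can be read: the limit of < 5% in this assay, at which 2 of the 3 values shown sit.

As far as these compounds go, whether azido in place of chloro on an aromatic carbon shifts inhibition at all in this assay remains open.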